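Replacing a benzyl group on the ring nitrogen of the core

This account rests on a few compounds, and the source may have more. Where it says the series, first, only, none or still open, it means among the compounds named here.

Of the compounds shown here, three sharing one core have been measured in a functional assay on HL-60 cells (Homo sapiens) for antiproliferative activity, with a stated time of 24 h; a higher number here means a weaker inhibitor, a lower number a stronger inhibitor. Compound 1, `N#Cc1ccccc1CN1CCc2c(sc(NC(=O)c3ccccc3Cl)c2C(N)=O)C1`, gives 10400 nM. Compound 2, `NC(=O)c1c(NC(=O)c2ccc(C(F)(F)F)cc2)sc2c1CCN(Cc1ccc(Cl)cc1Cl)C2`, gives 14900 nM, and compound 3, `NC(=O)c1c(NC(=O)c2cccc([N+](=O)[O-])c2)sc2c1CCN(Cc1ccc(Cl)cc1Cl)C2`, gives 19800 nM. Compound 1 has the lowest of the three numbers, but its distance to compound 2 and to compound 3 is within the scatter, so no order among the three can be claimed. Within the data shown here, the only single-point step, a 1.3-fold higher number from compound 2 to compound 3 (0.12 log units; within the scatter), concerns the group on the carbonyl carbon and also stays within the scatter.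

Compound 4, `NC(=O)c1c(NC(=O)c2ccccc2Cl)sc2c1CCN(C(=S)Nc1ccccc1)C2`, keeps the amide side of compound 1 and changes the other end: a group of 9 heavy atoms (7 carbon, 1 nitrogen, 1 sulfur; one six-membered aromatic ring of carbon only) in place of a group of 9 heavy atoms (8 carbon, 1 nitrogen; one six-membered aromatic ring of carbon only), on an amine nitrogen in a ring. Among the measured compounds shown here, none of the measured steps touches this ring nitrogen, so nothing in the data shows how this assay responds to a change there. For the measured compounds named here, the one step that exists, on the carbonyl side, was flat. Going by the values given here, with no bearing step to point in either direction, the expectation for this assay is a step from compound 1 to compound 4 of no clear size or direction, and the estimated step of a 1.1-fold higher number from compound 1 to compound 4 (0.02 log units; within the scatter) is therefore close to nothing. Compound 4 is expected to give about 11000 nM, with a range from 3000 nM to 40000 nM.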

Compound 4, half-maximal inhibitory concentration: 5940 nM
The estimate for compound 4 lay 1.9-fold (0.27 log units) above the measured number; the measured number falls inside the stated range.
By their numbers in this assay, from the lowest: compounds 4, 1, 2 and 3 (each within the scatter of the next, the first and the last beyond it).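

In this assay, the exchange of the 2-cyanobenzyl group for the sulfur-bearing group with no common name, on an amine nitrogen in a ring, gives a 1.8-fold lower number from compound 1 to compound 4 (0.24 log units; within the scatter) and thus stays within the scatter. Among these compounds, this is the first reading at this ring nitrogen, and it shows that a group with the same count of heavy atoms and one six-membered aromatic ring of carbon only can take the place of 2-cyanobenzyl without a change that can be told from repeat measurement, even though it brings sulfur and a hydrogen-bond donor that the 2-cyanobenzyl group lacks. Nothing available explains this result or links any feature of either group to the reading in this assay.

A single step within the scatter cannot show whether this ring nitrogen matters at all for the reading, and the sulfur and the added donor cannot be separated from each other here. The compounds shown also leave open what a much smaller or differently built group at this nitrogen, such as a methyl, an acetyl or a chain ending in a carboxylic acid, would do.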